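This account rests on a few compounds, and the source may have more. Where it says the series, first, only, none or still open, it means among the compounds named here.

Compound 1 `Fc1ccc(Nc2nc3nonc3nc2Nc2ccccc2F)cc1` gives 2300 nM in an assay on mitochondria from L6 cells (Rattus norvegicus) for activation, with a stated time of 90 min; a higher number here means that more compound is needed for the effect, a lower number that less compound is needed.
Compound 2 `O=C(Nc1ccc(Nc2nc3nonc3nc2Nc2ccccc2F)cc1)C(F)(F)F` gives 4100 nM in this assay.
Compound 3 `Fc1ccccc1Nc1nc2nonc2nc1Nc1ccc(OC(F)(F)F)cc1` gives 1300 nM in this assay.

Among these three numbers compound 1 stands second highest: its nearest neighbour is compound 3, at a 1.8-fold lower number from compound 1 to compound 3 (0.25 log units; within the scatter), and its furthest is compound 2, at a 1.8-fold higher number from compound 1 to compound 2 (0.25 log units; within the scatter). Compound 4 `Fc1ccccc1Nc1nc2nonc2nc1Nc1ccccn1` differs from compound 1 by pyridin-2-yl in place of 4-fluorophenyl on a nitrogen on an aromatic ring. Among the measured compounds shown here, no measured step makes this kind of change; the three measured compounds vary only a group on an aromatic carbon, and even the largest of those steps, a 3.2-fold lower number from compound 2 to compound 3 (0.50 log units; beyond the scatter), is modest. The shared core has so far tolerated such variation without large movement, so only a small to modest step in this assay is expected, with direction uncertain. The estimate for compound 4 is 3500 nM, with a range of 1000 nM to 12000 nM, meaning an expected 1.5-fold higher number from compound 1 to compound 4 (0.18 log units; within the scatter).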

Compound 4, half-maximal effective concentration: 9000 nM
Estimate against measurement, compound 4: 2.6-fold (0.41 log units) below; low and high end bracket the measured number.
By their numbers in this assay, from the lowest: compounds 3, 1 and 2 (each within the scatter of the next, the first and the last beyond it); then compound 4.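

In this assay, pyridin-2-yl in place of 4-fluorophenyl on a nitrogen on an aromatic ring gives a 3.9-fold higher number from compound 1 to compound 4 (0.59 log units; beyond the scatter). Of the steps from compound 1, this is the only one beyond the scatter, so exchanging this whole ring moves the number more than either change of a group on an aromatic carbon. Nothing available explains this step. The compounds shown leave open whether the step follows from the entering ring nitrogen or the leaving fluorine. They also leave open how unsubstituted phenyl, pyridin-3-yl or an amine-bearing phenyl would read in this assay.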